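Putting a nitro group on compound 1

This account rests on a few compounds, and the source may have more. Where it says the series, first, only, none or still open, it means among the compounds named here.

Measured in a functional assay on Bel-7402 cells (Homo sapiens) for cytotoxicity, read by MTT assay, with a stated time of 72 h; a lower number here means a stronger inhibitor, a higher number a weaker inhibitor:
- compound 1 `O=C1C=CCC/C1=C\C=C\c1ccccc1`: 4200 nM
- compound 2 `Cc1ccc(/C=C/C=C2\CCC=CC2=O)cc1`: 6300 nM

Among the measured compounds shown here, only these two compounds have numbers so far. In this assay, for the measured compounds named here, the value of compound 1 lies within the scatter of compound 2, its only measured neighbour, so neither can be ranked ahead of the other.

The next compound, compound 3 `O=C1C=CCC/C1=C\C=C\c1ccccc1[N+](=O)[O-]`, keeps the core of compound 1 and differs from it in one place: nitro in place of hydrogen on an aromatic carbon.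

Going by the values given here, one measured step bears on this change, methyl in place of hydrogen on an aromatic carbon, and it is a 1.5-fold higher number from compound 1 to compound 2 (0.18 log units; within the scatter). Among the compounds with values here, that step involves a different group, and no measured compound carries nitro, so it is only a loose guide. On this evidence, no step beyond the scatter is expected in this assay, and no direction can be favoured, although the uncertainty remains wide.

The expected step is a 1.1-fold lower number from compound 1 to compound 3 (0.02 log units; within the scatter).

Compound 3 is estimated at 4000 nM, with an expected range from 1300 nM to 12000 nM.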

Compound 3, half-maximal inhibitory concentration: 4600 nM
Compound 3: middle estimate off by 1.2-fold (0.06 log units), on the low side; low and high end bracket the measured number.
By their numbers in this assay, from the lowest: compounds 1, 3 and 2 (each within the scatter of the next).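

In this assay, nitro in place of hydrogen on an aromatic carbon, ortho to a large group, gives a 1.1-fold higher number from compound 1 to compound 3 (0.04 log units; within the scatter), so a group of three heavy atoms at this position of the aromatic ring produces no change beyond the scatter. Until now, the only measured replacement of hydrogen on this ring was methyl, with a 1.5-fold higher number from compound 1 to compound 2 (0.18 log units; within the scatter), and the new result extends the same outcome to a second, different group, one that brings nitrogen and oxygen onto the ring. No measured information is available on why the nitro compound falls where it does.

The compounds shown leave open whether an amine, a carboxylic acid or a methoxy group in this same place would move the number beyond the scatter, or whether the aromatic ring tolerates any such replacement without limit. They also leave open what a change to the shared core would do, such as removing the carbonyl or replacing the chain that links it to the aromatic ring with a longer chain.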